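Benzyl-substituted fused bicyclic series: bromo to nitro step

A few compounds are considered here, and "the series" means these few. Any claim that something is new, unique, unknown or untested is made for them only; others in the source may bear on it.

Measured so far:
compound 1 `Clc1ccc(-c2cn3nc(Cc4ccccc4)sc3n2)cc1`: 12000 nM
compound 2 `O=Cc1c(-c2ccc(Br)cc2)nc2sc(Cc3ccccc3)nn12`: 28200 nM

In a functional assay on cells (Cancer cell lines, Homo sapiens) for inhibition (a higher number here means a weaker inhibitor of growth, a lower number a stronger inhibitor of growth), compound 2 gives 28200 nM, the higher of the two numbers, and the gap to compound 1 lies beyond the usual scatter. Compound 3 `O=Cc1c(-c2ccc([N+](=O)[O-])cc2)nc2sc(Cc3ccccc3)nn12` carries nitro in place of bromo on an aromatic carbon. Among the compounds with values here, no measured pair in this set shows this change, so its effect is unknown; no step beyond the scatter is expected in either direction. For compound 3 the expected step is a 1.0-fold lower number from compound 2 to compound 3 (0.00 log units; within the scatter), within the scatter. Compound 3 is estimated at 28000 nM, with a range from 10000 nM to 80000 nM.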

Compound 3, concentration for total growth inhibition: 26300 nM
For compound 3 the middle estimate is 1.1-fold (0.03 log units) above the measured one; the measured number falls inside the stated range.
By their numbers in this assay, from the lowest: compound 1; then compounds 3 and 2 (each within the scatter of the next).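

In this assay, nitro in place of bromo on an aromatic carbon, para to a large group, gives a 1.1-fold lower number from compound 2 to compound 3 (0.03 log units; within the scatter), within the scatter. At this position, the series therefore does not separate these two groups, although the change adds heavy atoms and hydrogen-bond acceptors. No available data bear on why the number holds.

As far as these compounds go, whether an amine or a carboxylic acid at this position would give a different number remains open. Compound 1 differs from compound 2 in more than one place, so the gap between them cannot be assigned to a single change.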